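The source may report more compounds than this note shows. Statements on the series, on what has been measured and on what is new or still open speak of the compounds shown alone.

Measured compounds:
- compound 1, `N#Cc1c(N2CCC(c3ccccc3)CC2)ccn(CC2CCC2)c1=O`, 55 nM
- compound 2, `N#Cc1c(N2CCC(c3ccccc3F)CC2)ccn(CC2CC2)c1=O`, 81 nM

Both were tested in a functional assay on CHO cells for positive allosteric modulation of metabotropic glutamate receptor 2 (Homo sapiens), with a stated time of 30 min; a higher number here means that more compound is needed for the effect, a lower number that less compound is needed. Compound 2, with its result of 81 nM, has the higher of the two numbers, but its distance from compound 1 is given as within the scatter, so the two compounds cannot be told apart on these numbers.

Compound 3, `COc1ccc(C2CCN(c3ccn(CC4CC4)c(=O)c3C#N)CC2)cc1`, has not yet been measured. It differs from compound 2 in one place: 4-methoxyphenyl in place of 2-fluorophenyl on a saturated ring carbon. Going by the values given here, no step between measured compounds bears on this change, since compound 1 and compound 2 differ in two places at once and only their two values are known. There is therefore no measured basis for a shift in either direction in this assay, and the expectation is for a step that stays within the scatter.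

The estimated step from compound 2 to compound 3 is a 1.2-fold higher number from compound 2 to compound 3 (0.09 log units; within the scatter). Compound 3 is accordingly expected to give about 100 nM, with a plausible range from 35 nM to 300 nM.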

Compound 3, half-maximal effective concentration: 98 nM
The estimate for compound 3 lay 1.0-fold (0.01 log units) above the measured number; measured number inside the range.
By their numbers in this assay, from the lowest: compounds 1, 2 and 3 (each within the scatter of the next).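

In this assay, going by these compounds alone, the exchange of 2-fluorophenyl for 4-methoxyphenyl on the saturated ring carbon gives a 1.2-fold higher number from compound 2 to compound 3 (0.08 log units; within the scatter), and this is the first step in the set that alters only this group. On these numbers, compound 2 and compound 3 cannot be told apart, although the entering group has one more heavy atom and, unlike the group it replaces, counts a hydrogen-bond acceptor. At this place, three ring bonds from the ring nitrogen, the aromatic ring can therefore carry either of these two substituents, in their different named positions, without a difference that stands clear of the scatter. Nothing available explains why the two results lie so close together.

This single step alters the substituent and its position on the aromatic ring together, so the compounds shown cannot separate the effect of removing 2-fluoro from that of introducing 4-methoxy, a question that 4-fluorophenyl or 2-methoxyphenyl would address. From the compounds shown here alone, it also remains open whether this tolerance extends to very different groups at the same place, such as a carboxylic acid, an amine or a longer chain on the aromatic ring.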